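The source may hold more compounds than are shown below. What is called first, only, known or untested is meant among the compounds shown, and "the series" means these compounds.

Measured so far in an ADME assay on RD cells (Homo sapiens) for cytotoxicity, read by neutral red uptake, with a stated time of 3 days; on this read-out lower numbers stand for higher toxicity in this test and higher numbers for lower toxicity in this test:

compound 1 `CN(C)CCCNC(=O)c1cc(-c2ccccc2)nc2ccccc12`: 44900 nM
compound 2 `CC(C)Oc1cc(C(=O)NC2CCN(C)CC2)c2ccccc2n1`: 101000 nM
compound 3 `CN(C)CCCNC(=O)c1cc(-c2cccs2)nc2ccccc12`: 40500 nM

Compound 3 has the lowest number of the three. Compound 1 lies nearest to it, and the gap between the two falls within the scatter, so no order between compound 1 and compound 3 can be read; the gap to compound 2 lies beyond the scatter, compound 2 giving the higher number. Among the compounds with values here, the single one-place step among the measured compounds is a 1.1-fold lower number from compound 1 to compound 3 (0.04 log units; within the scatter), a change on the aromatic carbon of the shared core that left the read-out unmoved.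

Compound 4 `O=C(NCCCn1ccnc1)c1cc(-c2cccs2)nc2ccccc12` is next. It differs from compound 3 by 1H-imidazol-1-yl in place of dimethylamino on a saturated chain carbon, three bonds along the chain from an amide-type nitrogen. No measured step touches that part of the chain; the only step shown, a 1.1-fold lower number from compound 1 to compound 3 (0.04 log units; within the scatter), concerns another place and stayed within the scatter. With nothing pointing either way, the expectation for this assay is a step from compound 3 to compound 4 of about a 1.1-fold higher number from compound 3 to compound 4 (0.05 log units; within the scatter), that is, none beyond the scatter. Compound 4 is therefore estimated at 45000 nM, with a range from 18000 nM to 110000 nM.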

Compound 4, half-maximal cytotoxic concentration: 55700 nM
Compound 4: the middle estimate sits 1.2-fold (0.09 log units) below what was measured; the measured number falls inside the stated range.
By their numbers in this assay, from the lowest: compounds 3, 1, 4 and 2 (each within the scatter of the next, the first and the last beyond it).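

In this assay, within the data shown here, the first step at the chain end is a 1.4-fold higher number from compound 3 to compound 4 (0.14 log units; within the scatter) and so gives no readable shift. The open dimethylamino group can therefore give way to 1H-imidazol-1-yl, a five-membered aromatic ring, on the 3-carbon-linked chain of compound 3 without moving this read-out beyond the scatter. Nothing available explains why the number holds at this place.

As far as these compounds go, whether the same swap stays as quiet with phenyl on the aromatic carbon, as in compound 1, remains open. Also open, from the compounds shown here alone, is how the read-out responds to a morpholine or a carboxylic acid at the chain end, or to a longer chain carrying 1H-imidazol-1-yl.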